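The source may hold more compounds than are shown below. What is called first, only, known or untested is meant among the compounds shown, and "the series" means these compounds.

Working notes on the series. The two measured compounds share one core and differ only in the group that sits next to the ring nitrogen, meta to a fused ring and para to a fused ring. Compound 1 `COc1ccc2c(O[C@H]3C[C@H]4C(=O)N(C)CCCC/C=C/[C@@H]5C[C@@]5(C(=O)NS(=O)(=O)C5(C)CC5)NC(=O)N4C3)cc(-c3nc(C(F)(F)F)cs3)nc2c1C` gives 75000 nM in an ADME assay on Huh-7 cells (Homo sapiens) for cytotoxicity, read by colorimetric assay; a higher number here means that more compound is tolerated, a lower number that less compound is tolerated. Compound 2 `COc1ccc2c(O[C@H]3C[C@H]4C(=O)N(C)CCCC/C=C/[C@@H]5C[C@@]5(C(=O)NS(=O)(=O)C5(C)CC5)NC(=O)N4C3)cc(C#N)nc2c1C` gives 55800 nM in this assay; it holds the lowest of the two numbers, and its nearest neighbour, compound 1, differs from it by a 1.3-fold lower number from compound 1 to compound 2 (0.13 log units; within the scatter), a step that stays within the scatter.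

Compound 3 `C#Cc1cccc(-c2cc(O[C@H]3C[C@H]4C(=O)N(C)CCCC/C=C/[C@@H]5C[C@@]5(C(=O)NS(=O)(=O)C5(C)CC5)NC(=O)N4C3)c3ccc(OC)c(C)c3n2)c1` is not yet measured. It differs from compound 2 by 3-ethynylphenyl in place of cyano on an aromatic carbon. Among the measured compounds shown here, the only measured step that bears on this position is a 1.3-fold lower number from compound 1 to compound 2 (0.13 log units; within the scatter), where an aromatic group was replaced by cyano and the number barely moved. Compound 3 reverses that direction and puts an aromatic group back in place of cyano, so no step beyond the scatter is expected in this assay; the estimated step is a 1.1-fold higher number from compound 2 to compound 3 (0.03 log units; within the scatter). For compound 3 a value of 60000 nM is therefore expected, with a range from 25000 nM to 150000 nM.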

Compound 3, half-maximal cytotoxic concentration: 75000 nM
For compound 3 the middle estimate is 1.3-fold (0.10 log units) below the measured one; measured number inside the range.
By their numbers in this assay, from the lowest: compounds 2, 1 and 3 (each within the scatter of the next).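

At this place, next to the ring nitrogen, the step from the 2 heavy atoms of cyano to the 8 heavy atoms of 3-ethynylphenyl gives a 1.3-fold higher number from compound 2 to compound 3 (0.13 log units; within the scatter) in this assay, so this larger group with its six-membered aromatic ring of carbon only still leaves the number within the scatter. Exchanging one aromatic group for another, 3-ethynylphenyl for 4-(trifluoromethyl)-1,3-thiazol-2-yl, gives no change at the digits printed from compound 1 to compound 3 (within the scatter), so this read-out does not separate a ring of carbon only from the thiazole, a comparison that the earlier pair could not offer. Nothing available here accounts for the three compounds staying within the scatter of one another.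

From the compounds shown here alone, all the steps at this place remain within the scatter, so it stays open whether any group here can move the number beyond it, for example an amine, a carboxylic acid or a saturated ring such as cyclohexyl. A plain phenyl would be needed to tell whether the ethynyl of 3-ethynylphenyl plays any part in this number.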